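Methoxy for Methyl on a Shared Core

This account rests on a few compounds, and the source may have more. Where it says the series, first, only, none or still open, it means among the compounds named here.

Compound 1, `Cc1ccc(Cc2nc(N)n(CC(=O)Nc3ccccc3)c2-c2ccccc2Br)cc1`: 9200 nM
Compound 2, `COc1ccc(Cc2nc(N)n(CC(=O)Nc3ccccc3)c2-c2ccccc2Br)cc1`: 3200 nM
Compound 3, `Cc1ccc(Cc2nc(N)n(CC(=O)Nc3ccc(C)cc3)c2-c2ccccc2Br)cc1`: 2900 nM

These three compounds share one core and were measured in a functional assay on MIA PaCa-2 cells (Homo sapiens) for antiproliferative activity, read by MTT assay, with a stated time of 48 h; a higher number here means a weaker inhibitor, a lower number a stronger inhibitor. Compound 2 differs from compound 1 by methoxy in place of methyl on an aromatic carbon, which gave a 2.9-fold lower number from compound 1 to compound 2 (0.46 log units; beyond the scatter). Compound 3 differs from compound 1 by methyl in place of hydrogen on an aromatic carbon, which gave a 3.2-fold lower number from compound 1 to compound 3 (0.50 log units; beyond the scatter). Compound 2 and compound 3 lie within the scatter of each other, so no order between them is claimed.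

The unmeasured compound 4, `COc1ccc(Cc2nc(N)n(CC(=O)Nc3ccc(C)cc3)c2-c2ccccc2Br)cc1`, combines both alterations. It differs from compound 3 by methoxy in place of methyl on an aromatic carbon. This is the same change as the one made from compound 1 to compound 2, carried out in two places among these compounds, here on the core of compound 3 rather than that of compound 1; the two cores differ as already described. Compound 4 is expected to give 1300 nM, within 500 nM to 3500 nM. The expected step of a 2.2-fold lower number from compound 3 to compound 4 (0.35 log units; beyond the scatter) is kept somewhat smaller than a 2.9-fold lower number from compound 1 to compound 2 (0.46 log units; beyond the scatter) because compound 2 with 3200 nM and compound 3 with 2900 nM already sit close, and whether the two changes add together has not been tested.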

Compound 4, half-maximal inhibitory concentration: 5200 nM
Estimate against measurement, compound 4: 4.0-fold (0.60 log units) below, outside the stated range (above it).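

In this assay, methoxy in place of methyl on an aromatic carbon did not carry over from the core of compound 1 to the core of compound 3, where it gave a 1.8-fold higher number from compound 3 to compound 4 (0.25 log units; within the scatter), and the two steps differ: the same change on two cores in this assay, a 2.9-fold lower number (0.46 log units; beyond the scatter) from compound 1 to compound 2 and a 1.8-fold higher number (0.25 log units; within the scatter) from compound 3 to compound 4, 5.2-fold (0.71 log units) apart, beyond the scatter of two such steps. Methyl in place of hydrogen on an aromatic carbon behaved alike, giving a 1.6-fold higher number from compound 2 to compound 4 (0.21 log units; within the scatter) on the core of compound 2, again unlike the step on the core of compound 1: the same change on two cores in this assay, a 3.2-fold lower number (0.50 log units; beyond the scatter) from compound 1 to compound 3 and a 1.6-fold higher number (0.21 log units; within the scatter) from compound 2 to compound 4, 5.2-fold (0.71 log units) apart, beyond the scatter of two such steps. Thus the size of either step depended on the core within these four compounds, but both new steps lie within the scatter, so no order among compound 2, compound 3 and compound 4 is claimed, and the data do not show why the steps differ or how the changes would behave on any other core.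

The compounds shown leave open whether an ethoxy group or a chlorine atom in place of the methoxy of the 4-methoxybenzyl would show the same dependence on the core. They also leave open how an amine or a carboxylic acid in place of the methyl of the 4-methylphenyl would behave.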